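The source may report more compounds than this note shows. Statements on the series, on what has been measured and on what is new or still open speak of the compounds shown alone.

Measured compounds:
Compound 1 `CCCCCn1c(-c2ccco2)nc2c(NCc3ccccc3)ccnc21` — > 200000 nM
Compound 2 `CCCCCn1c(-c2ccco2)nc2c(NCCOC)ccnc21` — > 200000 nM

Compound 1 was tested in an assay on isolated protein for inhibition of high affinity 3',5'-cyclic-AMP phosphodiesterase 7A (Homo sapiens), read by cAMP accumulation, with a stated time of 20 min; on this read-out higher numbers stand for weaker inhibition and lower numbers for stronger inhibition. In this assay compound 1 gives > 200000 nM, which is a limit of the assay and not a number. Compound 2 gives > 200000 nM in this assay, again a limit rather than a number. Going by the values given here, compound 2 therefore stands at the edge of what the assay can report, and the only step connecting it to another measured compound, a step that the two limits leave unreadable from compound 1 to compound 2, cannot be sized because of the limit of > 200000 nM in this assay, at which 2 of the 2 values shown sit.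

Compound 3 `CCCCCn1c(-c2ccco2)nc2c(N(C)CCCO)ccnc21` is the next compound; it differs from compound 2 by (3-hydroxypropyl)(methyl)amino in place of (2-methoxyethyl)amino on an aromatic carbon. Among the compounds with values here, no measured step bears on this change, as both known values are limits. Compound 3 is expected to give 200000 nM, in a range from 50000 nM to 400000 nM. The expected step from compound 2 to compound 3 is a number no higher from compound 2 to compound 3 (the limit leaves the size open), no shift beyond the scatter.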

Compound 3, half-maximal inhibitory concentration: 18900 nM
Compound 3: middle estimate off by 11-fold (1.02 log units), on the high side, and the stated range ends above it.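

Going by these compounds alone, compound 3 is the first compound here with a readable number in this assay, which shows that a change at this aromatic carbon, opposite the ring nitrogen, can register on the read-out. Placing (3-hydroxypropyl)(methyl)amino here gives an at least 10-fold lower number from compound 2 to compound 3 (1.02 log units; beyond the scatter), and the comparison with benzylamino gives an at least 10-fold lower number from compound 1 to compound 3 (1.02 log units; beyond the scatter), so inhibition is stronger with this group than with either earlier one. Each step sets only a minimum size, because compounds 1 and 2 stop at a limit rather than a number: the limit of > 200000 nM in this assay, at which 2 of the 3 values shown sit.

The new group differs from (2-methoxyethyl)amino in both its chain and the methyl on its nitrogen, and the compounds shown do not separate these two features. From the compounds shown here alone, it also remains open whether the hydroxyl itself matters, a question that a primary amine or carboxylic acid at the chain end could address.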